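Ester chain length and cytotoxicity on A549 cells

The compounds below may be only part of what the source reports. "The series", "measured", "known", "first", "only" and "open" are said of these compounds alone.

Measured compounds:
compound 1 `CCOC(=O)CCC(=O)N1CCN(CCCOc2cc3c(Nc4ccc(F)c(Cl)c4)ncnc3cc2OC)CC1` gives 67.4% in a functional assay on A549 cells (Homo sapiens) for cytotoxicity, read by MTT assay, with a stated time of 24 h, tested at 40 uM; on this read-out lower numbers stand for a stronger effect and higher numbers for a weaker effect at the one concentration tested
compound 2 `CCCCCCCOC(=O)CCC(=O)N1CCN(CCCOc2cc3c(Nc4ccc(F)c(Cl)c4)ncnc3cc2OC)CC1` gives 59.1% in this assay

Compound 2 holds the lower of the two numbers, yet the step of a number 8.3 percentage points lower from compound 1 to compound 2 (within the scatter) lies within the scatter. Compound 3 `CCCCCCCCOC(=O)CCC(=O)N1CCN(CCCOc2cc3c(Nc4ccc(F)c(Cl)c4)ncnc3cc2OC)CC1` differs from compound 2 by methyl in place of hydrogen on a saturated chain carbon, seven bonds along the chain from an oxygen next to a carbonyl group. For the measured compounds named here, that change is a shorter version of the one that gave a number 8.3 percentage points lower from compound 1 to compound 2 (within the scatter), and that step was within the scatter, so no step beyond the scatter is expected in this assay; the expected step of a number 3.1 percentage points lower from compound 2 to compound 3 (within the scatter) is small. Compound 3 is therefore estimated at 56%, between 44% and 68%.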

Compound 3, a percentage reported as activity, at one concentration (the size of the read-out at that concentration, not a potency): 48.7%
Compound 3: the middle estimate sits 7.3 percentage points above what was measured; low and high end bracket the measured number.
By their numbers in this assay, from the lowest: compound 3; then compounds 2 and 1 (each within the scatter of the next).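

In this assay, methyl in place of hydrogen, seven bonds along the chain from an oxygen next to a carbonyl group, gives a number 10.4 percentage points lower from compound 2 to compound 3 (beyond the scatter), so a single added carbon at this place now produces a step beyond the scatter, which the earlier pair did not show. Hexyl in place of hydrogen, two bonds along the chain from that oxygen, gives a number 18.7 percentage points lower from compound 1 to compound 3 (beyond the scatter). Nothing available explains these steps. As far as these compounds go, whether a longer chain would give a lower number still, or how an amine or a carboxylic acid in place of the methyl would read, stays open.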